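The source may report more compounds than this note shows. Statements on the series, on what has been measured and on what is new or still open speak of the compounds shown alone.

Of the compounds shown here, three that share one core have been tested in a functional assay on HeLa cells (Homo sapiens) for inhibition, read by MTT assay, with a stated time of 48 h; a higher number here means a weaker inhibitor, a lower number a stronger inhibitor. Compound 1 `COc1ccc2c(=O)c(/C=C/C(=O)Nc3cccc(C)c3)coc2c1` carries a 3-methylphenyl on the amide-type nitrogen. In this assay compound 1 gives > 100000 nM, which is a limit of the assay and not a number. Compound 2 `COc1ccc(CNC(=O)/C=C/c2coc3cc(O)ccc3c2=O)cc1` carries a 4-methoxybenzyl on that nitrogen and a hydrogen on an oxygen on an aromatic ring. In this assay compound 2 gives > 100000 nM, again a limit rather than a number. Compound 3 `COc1ccc(CNC(=O)/C=C/c2coc3cc(OC)ccc3c2=O)cc1` differs from compound 2 by a methyl in place of that hydrogen. In this assay compound 3 gives > 100000 nM, which is also a limit. For that reason the steps a step that the two limits leave unreadable from compound 1 to compound 3 and a step that the two limits leave unreadable from compound 2 to compound 3 cannot be sized; what is known of them is the limit of > 100000 nM in this assay, at which 3 of the 3 values shown sit.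

The compound not yet measured is compound 4 `O=C(/C=C/c1coc2cc(O)ccc2c1=O)NCc1ccc(F)cc1F`. Its change from compound 2 is 2,4-difluorophenyl in place of 4-methoxyphenyl on a saturated chain carbon bound to an amide-type nitrogen. Going by the values given here, no measured step touches this change, and the two measured steps that exist are unreadable, so there is no basis for expecting a move beyond the scatter. The expected step that the limit leaves unreadable from compound 2 to compound 4 is close to none, with a fair chance that only a limit is reported once more. Compound 4 is estimated at 150000 nM, with a range from 50000 nM to 500000 nM.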

Compound 4, half-maximal inhibitory concentration: > 100000 nM
Compound 4 gave a limit, no number; the forecaster's own chance of this, stated with the estimate: 85%; the middle value does not contradict the limit.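

In this assay compound 4 gives > 100000 nM, which is a limit and not a number. Compound 2 also gives only a limit, so no step can be read between compound 2 and compound 4. The compounds shown leave open whether any change to the shared core gives a measurable value, and all of them sit at one limit: the limit of > 100000 nM in this assay, at which 4 of the 4 values shown sit.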